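The source may hold more compounds than are shown below. What is called first, only, known or untested is meant among the compounds shown, and "the series" means these compounds.

Measured compounds and their values in an assay for inhibition of hexokinase-2 (Homo sapiens), read by coupled enzyme assay, with a stated time of 10 min, in the presence of a further agent that is not named here; a higher number here means a weaker inhibitor, a lower number a stronger inhibitor:

Compound 1, `C=C1CC[C@H]2[C@@](C)(CC[C@@H](OC(=O)c3ccccc3)[C@@]2(C)NC=O)[C@@H]1/C=C/C1=CCOC1=O` — compound 1 gives > 50000 nM, which is a limit of the assay and not a number.
Compound 2, `C=C1CC[C@H]2[C@@](C)(CC[C@@H](OC(=O)c3ccc([N+](=O)[O-])cc3)[C@@]2(C)NC=O)[C@@H]1/C=C/C1=CCOC1=O` — compound 2 gives > 50000 nM, again a limit.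
Compound 3, `C=C1CC[C@H]2[C@@](C)(CC[C@@H](OC(=O)[C@H](N)CC(C)C)[C@@]2(C)NC=O)[C@@H]1/C=C/C1=CCOC1=O` — compound 3 gives > 50000 nM, also a limit.

Where compound 3 stands: only a limit is known for it in this assay, and the two other values shown are limits as well, so no ordering among the three can be read. The step from compound 1 to compound 2, a step that the two limits leave unreadable from compound 1 to compound 2, the step from compound 1 to compound 3, a step that the two limits leave unreadable from compound 1 to compound 3, and the step from compound 2 to compound 3, a step that the two limits leave unreadable from compound 2 to compound 3, are all unreadable because of the limit of > 50000 nM in this assay, at which 3 of the 3 values shown sit.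

Compound 4, `C=C1CC[C@H]2[C@@](C)(CC[C@@H](OC(=O)[C@H]3CCCN3)[C@@]2(C)NC=O)[C@@H]1/C=C/C1=CCOC1=O`, has not yet been measured in this assay. It differs from compound 3 by pyrrolidin-2-yl in place of 1-amino-3-methylbutyl on a carbonyl carbon. Within the data shown here, none of the measured steps bears on this change in a readable way, as all three values sit at the limit. No step beyond the scatter can therefore be expected in either direction in this assay. The estimate for compound 4 is 80000 nM, between 30000 nM and 300000 nM, most likely reported again only as a limit. The expected step from compound 3 to compound 4 is a step that the limit leaves unreadable from compound 3 to compound 4.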

Compound 4, half-maximal inhibitory concentration: 26100 nM
Compound 4: middle estimate off by 3.1-fold (0.49 log units), on the high side; the whole stated range lies above it.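

In this assay, among these compounds, compound 4 gives 26100 nM, the first readable value for a group on this carbonyl carbon, so the shared core with a pyrrolidin-2-yl group there can register in the assay. Pyrrolidin-2-yl in place of 1-amino-3-methylbutyl gives an at least 1.9-fold lower number from compound 3 to compound 4 (0.28 log units; that floor lies within the scatter), in place of 4-nitrophenyl it gives an at least 1.9-fold lower number from compound 2 to compound 4 (0.28 log units; that floor lies within the scatter), and in place of phenyl it gives an at least 1.9-fold lower number from compound 1 to compound 4 (0.28 log units; that floor lies within the scatter). The full size of these steps stays unread, and no gain beyond the scatter can be claimed, because only a floor is available: the limit of > 50000 nM in this assay, at which 3 of the 4 values shown sit.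

Open, as far as these compounds go, is whether the ring nitrogen is needed, which a cyclopentyl group at this place would test. Also open, from the compounds shown here alone, is how a piperidin-2-yl group, or a methyl on the pyrrolidine nitrogen, compares with compound 4.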